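This account rests on a few compounds, and the source may have more. Where it says the series, first, only, none or still open, it means among the compounds named here.

In a functional assay on Shh Light II cells (Mus musculus) for inhibition, read by a luciferase reporter (a lower number here means a stronger inhibitor, a higher number a weaker inhibitor), compound 3 (`COc1ccccc1N(C)C(=O)N1CCC(c2nc(-c3ccc4ccccc4n3)no2)CC1`) gives 3100 nM, the highest number of the three measured. Compound 1 (`CC(C)c1ccccc1NC(=O)N1CCC(c2nc(-c3ccc4ccccc4n3)no2)CC1`) gives 480 nM and compound 2 (`O=C(NC1CCS(=O)(=O)CC1)N1CCC(c2nc(-c3ccc4ccccc4n3)no2)CC1`) gives 360 nM. Compound 4 (`COc1ccccc1NC(=O)N1CCC(c2nc(-c3ccc4ccccc4n3)no2)CC1`) differs from compound 3 by hydrogen in place of methyl on an amide-type nitrogen. Going by the values given here, two measured steps bear on this, although each also changes the group on that nitrogen: a 6.5-fold higher number from compound 1 to compound 3 (0.81 log units; beyond the scatter) and an 8.6-fold higher number from compound 2 to compound 3 (0.94 log units; beyond the scatter). Both compounds with hydrogen there carry lower numbers than compound 3, so a step of similar size towards a lower number is expected in this assay. The expected change is a 5.2-fold lower number from compound 3 to compound 4 (0.71 log units; beyond the scatter). For compound 4 the estimate is 600 nM, with an expected range from 200 nM to 1800 nM.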

Compound 4, half-maximal inhibitory concentration: 410 nM
Beside the measured number, compound 4's estimate is 1.5-fold (0.17 log units) above it, within the range that was stated.
By their numbers in this assay, from the lowest: compounds 2, 4 and 1 (each within the scatter of the next); then compound 3.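

In this assay, going by these compounds alone, the methyl on the amide-type nitrogen is now the only thing that changes: hydrogen in its place gives a 7.6-fold lower number from compound 3 to compound 4 (0.88 log units; beyond the scatter) with the 2-methoxyphenyl group kept. With hydrogen on that nitrogen, the group carried there matters little among these compounds, since a 1.2-fold lower number from compound 1 to compound 4 (0.07 log units; within the scatter) for methoxy in place of isopropyl on an aromatic carbon and a 1.1-fold higher number from compound 2 to compound 4 (0.06 log units; within the scatter) for 2-methoxyphenyl in place of 1,1-dioxothian-4-yl both lie within the scatter. No measurement at hand accounts for the effect of the methyl.

Going by these compounds, whether methyl on the same nitrogen of compound 1 or compound 2 has a similar effect stays open. So does the outcome with an ethyl there.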